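The source may hold more compounds than are shown below. What is called first, only, known or untested is meant among the compounds shown, and "the series" means these compounds.

Working notes on the dithiol anilides and their thioacetyl-protected analogues.

Compound 1 `O=C(CCCCC(S)CCS)Nc1ccccc1` is the parent free dithiol; in a functional assay on NCI-H460 cells (Homo sapiens) for inhibition, read by MTT assay, with a stated time of 24 h, tested at 100 ug/mL (on this read-out lower numbers stand for less inhibition of growth and higher numbers for more inhibition of growth at the one concentration tested), compound 1 gives 25.4%. Compound 2 `O=C(CCCCC(S)CCS)Nc1ccc(Cl)cc1` carries the change (chloro in place of hydrogen on an aromatic carbon). In this assay compound 2 gives 40.9%, so the step of a number 15.5 percentage points higher from compound 1 to compound 2 (beyond the scatter). Compound 3 `CC(=O)SCCC(CCCCC(=O)Nc1ccccc1)SC(C)=O` has the core of compound 1 with both thiols acylated; the difference between the two cores is not broken down here. In this assay compound 3 gives 44.8%, which against compound 2 lies within the scatter and against compound 1 beyond it.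

Compound 4 `CC(=O)SCCC(CCCCC(=O)Nc1ccccc1Cl)SC(C)=O` is not yet measured; it differs from compound 3 by chloro in place of hydrogen on an aromatic carbon. This is the same kind of change as from compound 1 to compound 2, but not the same: there the chloro sits para to a large group, here ortho to a large group. Resting on the step of a number 15.5 percentage points higher from compound 1 to compound 2 (beyond the scatter) made on the free dithiol core, a step of a number 10.2 percentage points higher from compound 3 to compound 4 (beyond the scatter) in this assay is expected; the ortho placement leaves its size less certain. Compound 4 is estimated at 55%, between 38% and 70%.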

Compound 4, percent growth inhibition at one concentration: 15.2%
The estimate for compound 4 lay 39.8 percentage points above the measured number; the whole stated range lies above it.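

In this assay the chloro change on the thioacetyl-protected core gives a number 29.6 percentage points lower from compound 3 to compound 4 (beyond the scatter), so the step seen on the free dithiol core does not carry over in either direction or size: the same change on two cores in this assay, a number 15.5 percentage points higher (beyond the scatter) from compound 1 to compound 2 and a number 29.6 percentage points lower (beyond the scatter) from compound 3 to compound 4, 45.1 percentage points apart, beyond the scatter of two such steps. The two steps differ in two places at once, since the core changes and the chloro of compound 4 sits ortho to a large group, whereas the chloro of compound 2 occupies another ring position. The comparison therefore shows that a chloro step cannot be transferred from one core to the other in this series as it stands, but it does not show whether the core, the ring position or both account for the gap.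

The compounds shown leave open how a 2-chlorophenyl anilide behaves on the free dithiol core, and how the protected core responds with the chloro placed as in compound 2. Also open, going by these compounds, is whether a fluoro or methoxy group in place of the chloro would follow either step.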